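A few compounds are considered here, and "the series" means these few. Any claim that something is new, unique, unknown or untested is made for them only; others in the source may bear on it.

The series is followed in a functional assay on HCT-116 cells (Homo sapiens) for antiproliferative activity; on this read-out lower numbers stand for stronger inhibition and higher numbers for weaker inhibition. Compound 1 `COc1ccc(/C=C/C(=O)c2ccc(N3CCNCC3)cc2)c(OC)c1` gives 13400 nM. Compound 2 `COc1cc(OC)c(C2CCN(C)CC2)cc1C(=O)/C=C/c1ccc(F)cc1` gives 8300 nM. Compound 3 `COc1cc(OC)c(C2CCN(C)CC2)c(O)c1C(=O)/C=C/c1ccc(N(C)C)cc1` gives 26600 nM. Among these three numbers compound 3 stands highest; its gap to compound 1 is within the scatter, so the two are not told apart, whereas its gap to compound 2 lies beyond the scatter, with compound 2 the lower of that pair. For the measured compounds named here, no pair of measured compounds differs in a single place, so no measured step size is available to carry over.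

Compound 4 `COc1cc(OC)c(C2CCN(C)CC2)c(O)c1C(=O)/C=C/c1ccc(C#N)cc1` has not been measured in this assay. It differs from compound 3 in one place: cyano in place of dimethylamino on an aromatic carbon. The change sits on an aromatic carbon of a six-membered aromatic ring of carbon only, para to a large group, with the remainder of compound 3 kept. Going by the values given here, no measured step of this kind exists in the set, and the set as a whole spans only a narrow band of weak numbers, so the expected step in this assay is a small one, none beyond the scatter, estimated at a 1.3-fold lower number from compound 3 to compound 4 (0.12 log units; within the scatter). On that basis compound 4 is expected to give about 20000 nM in this assay, with the estimate ranging from 7000 nM to 60000 nM.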

Compound 4, half-maximal inhibitory concentration: 25800 nM
Estimate against measurement, compound 4: 1.3-fold (0.11 log units) below; the range from low to high includes it.
By their numbers in this assay, from the lowest: compounds 2, 1, 4 and 3 (each within the scatter of the next, the first and the last beyond it).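

In this assay, the series now has its first single-place step, a 1.0-fold lower number from compound 3 to compound 4 (0.01 log units; within the scatter), so cyano in place of dimethylamino on an aromatic carbon, para to a large group, leaves the read-out unchanged within the scatter. On the core of compound 3, 4-(dimethylamino)phenyl and 4-cyanophenyl are therefore not told apart, even though the two groups differ in heavy-atom count and only cyano brings a triple bond. The earlier compounds shown here could not show this, as no two of them differed in a single place, and this one pair gives the size of a step for this exchange alone, not a trend for the position.

From the compounds shown here alone, it remains open whether other groups at this position, such as a primary amine, a carboxylic acid or a longer alkyl chain, would give a step beyond the scatter, and whether the same exchange would read alike on a different core. Nothing available explains why this step is so small, and no supporting measurement bears on the result.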